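A methyl for a hydroxyl on the terminal aromatic ring

A few compounds are considered here, and "the series" means these few. Any claim that something is new, unique, unknown or untested is made for them only; others in the source may bear on it.

Compound 1 `Cc1ccc(S(=O)(=O)N[C@@H](CC(=O)NC(C)(C)C)C(=O)NCCNC(=O)c2c(O)cccc2F)cc1` carries a 2-fluoro-6-hydroxyphenyl group on a carbonyl carbon. In an ADME assay on Karpas-1106P cells (Homo sapiens) for cytotoxicity (a lower number here means that less compound is needed, a higher number that more compound is needed for the effect), compound 1 gave > 11100 nM, which is a limit of the test rather than a number. Compound 2 `Cc1ccc(S(=O)(=O)N[C@@H](CC(=O)NC(C)(C)C)C(=O)NCCNC(=O)c2ccc(F)cc2)cc1` carries a 4-fluorophenyl on that carbonyl carbon instead, and in this assay compound 2 likewise gave only the limit > 11100 nM. Compound 3 `Cc1ccc(S(=O)(=O)N[C@@H](CC(=O)NC(C)(C)C)C(=O)NCCNC(=O)c2ccc(Cl)cc2)cc1` carries a 4-chlorophenyl there, and in this assay compound 3 also stopped at the limit > 11100 nM. Because all three values sit at the limit of > 11100 nM in this assay, at which 3 of the 3 values shown sit, none of the steps among them can be read: a step that the two limits leave unreadable from compound 1 to compound 2, a step that the two limits leave unreadable from compound 1 to compound 3 and a step that the two limits leave unreadable from compound 2 to compound 3 are all of unreadable size. Compound 1 therefore stands at the limit alongside the other two, with no measured order among them.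

Compound 4 `Cc1ccc(S(=O)(=O)N[C@@H](CC(=O)NC(C)(C)C)C(=O)NCCNC(=O)c2cc(C)ccc2F)cc1` alters the same ring once more: 2-fluoro-5-methylphenyl in place of 2-fluoro-6-hydroxyphenyl on a carbonyl carbon. For the measured compounds named here, no measured step bears on this change with a readable size; the only guidance is that three different groups on this carbonyl carbon all gave the limit. The expectation for compound 4 is therefore no step beyond the scatter, a step that the limit leaves unreadable from compound 1 to compound 4, with compound 4 most likely reported as a limit again. Compound 4 is estimated at 15000 nM, between 5000 nM and 50000 nM.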

Compound 4, half-maximal effective concentration: > 11100 nM
Compound 4 gave a limit, no number; the forecaster's own chance of this, stated with the estimate: 85%; the middle value lies beyond the limit too.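

Compound 4 gave only a limit, just as compound 1, compound 2 and compound 3 did, so no step among these four compounds can be read: the limit of > 11100 nM in this assay, at which 4 of the 4 values shown sit.

The compounds shown leave open whether any group on this carbonyl carbon changes how much compound is needed in this assay; none of the four has given a number.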